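The source may hold more compounds than are shown below. What is called first, only, known or untested is meant among the compounds shown, and "the series" means these compounds.

Measured so far:
Compound 1 `CC(C)(C)OC(=O)N1CCN(C(=S)SCc2cn(-c3ccccc3F)nn2)CC1`. In a functional assay on PC-3 cells (Homo sapiens) for inhibition, read by MTT assay, with a stated time of 72 h (a higher number here means a weaker inhibitor, a lower number a stronger inhibitor), compound 1 gives > 128000 nM, a limit of the assay rather than a number.
Compound 2 `O=C(OCc1ccccc1)N1CCN(C(=S)SCc2cn(Cc3ccc(Cl)cc3)nn2)CC1`. In this assay compound 2 gives > 128000 nM, again a limit and not a number.

Compound 2 therefore stands at the limit of > 128000 nM in this assay, at which 2 of the 2 values shown sit; nothing separates it from compound 1 on the numbers shown, since both read-outs are limits. Within the data shown here, no measured step between the two compounds can be stated, as they differ in more than one place.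

Compound 3 `O=C(OCc1ccccc1)N1CCN(C(=S)SCc2cn(Cc3ccccc3F)nn2)CC1` carries, relative to compound 2, (2-fluorophenyl in place of 4-chlorophenyl on a saturated chain carbon bound to an aromatic nitrogen). Among the measured compounds shown here, no measured step covers this change, and the two values shown give no scale to work from. The expected step in this assay from compound 2 to compound 3 is none beyond the scatter, a number no higher from compound 2 to compound 3 (the limit leaves the size open), with the read-out for compound 3 most likely again reported as a limit. The estimate for compound 3 is 128000 nM, within 50000 nM to 300000 nM.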

Compound 3, half-maximal inhibitory concentration: 68300 nM
Estimate against measurement, compound 3: 1.9-fold (0.27 log units) above, within the range that was stated.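

In this assay compound 3 gives 68300 nM, the first read-out in the series that is a number and not a limit. Replacing 4-chlorobenzyl with 2-fluorobenzyl, on the saturated chain carbon bound to an aromatic nitrogen, gives an at least 1.8-fold lower number from compound 2 to compound 3 (0.27 log units; that floor lies within the scatter), so a change at this place alone can bring the read-out inside the measurable range. The full size of the step stays open, since compound 2 sits at a limit: the limit of > 128000 nM in this assay, at which 2 of the 3 values shown sit.

The compounds shown do not separate the identity of the halogen from its place on the ring, which a 2-chlorobenzyl or 4-fluorobenzyl group would begin to do. Also open, as far as these compounds go, is how an unsubstituted benzyl group or a longer chain carrying an amine would read at this place.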